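Hydroxyphenyl placement on a shared core against topoisomerase

This account rests on a few compounds, and the source may have more. Where it says the series, first, only, none or still open, it means among the compounds named here.

Measured compounds:
compound 1 `Oc1ccc(-c2cc(-c3ccc(O)cc3)nc(-c3ccc(O)cc3)c2)cc1`: 3.8%
compound 2 `Oc1ccccc1-c1cc(-c2ccccc2O)nc(-c2ccccc2O)c1`: 0%
compound 3 `Oc1ccc(-c2cc(-c3ccccc3O)cc(-c3ccc(O)cc3)n2)cc1`: 0.4%

In an assay on isolated protein for inhibition of DNA topoisomerase 1 (Homo sapiens), with a stated time of 30 min, tested at 100 uM (on this read-out lower numbers stand for less inhibition and higher numbers for more inhibition at the one concentration tested (going by the name of the read-out)), compound 1 gives 3.8%, compound 2 gives 0% and compound 3 gives 0.4%. The three numbers lie within the usual scatter of one another, so no ranking among them is supported.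

One single-point change is measured: 4-hydroxyphenyl in place of 2-hydroxyphenyl on an aromatic carbon. It moves the read-out by a number 3.4 percentage points higher from compound 3 to compound 1 (within the scatter).

The difference between the core of compound 2 and the core of compound 3 is not broken down here.

Compound 4 `Oc1ccc(-c2cc(-c3ccccc3O)nc(-c3ccccc3O)c2)cc1` is not yet measured. It differs from compound 2 by 4-hydroxyphenyl in place of 2-hydroxyphenyl on an aromatic carbon. Around the place the surroundings are not identical: in compound 3 the site is meta to two 4-hydroxyphenyl groups, in compound 2 it is meta to two 2-hydroxyphenyl groups, so this is the same kind of change, not the same change.

Because compound 3 to compound 1 gave a number 3.4 percentage points higher from compound 3 to compound 1 (within the scatter), a step of similar size, a number 2 percentage points higher from compound 2 to compound 4 (within the scatter), is expected for compound 2 to compound 4. Compound 4 is therefore estimated at 2% in this assay, between 0% and 8%.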

Compound 4, a percentage reported as inhibition, at one concentration (the size of the read-out at that concentration, not a potency): 3.7%
The estimate for compound 4 lay 1.7 percentage points below the measured number; low and high end bracket the measured number.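

In this assay, 4-hydroxyphenyl in place of 2-hydroxyphenyl, on the aromatic carbon opposite the ring nitrogen, gives a number 3.7 percentage points higher from compound 2 to compound 4 (within the scatter), and this can be set beside the earlier step: the same change on two cores in this assay, a number 3.4 percentage points higher (within the scatter) from compound 3 to compound 1 and a number 3.7 percentage points higher (within the scatter) from compound 2 to compound 4, 0.3 percentage points apart, within the scatter of two such steps. The change therefore reads the same on both cores, but since each step is itself within the scatter, what carries over is the absence of a resolved effect, not a demonstrated gain in inhibition. The data show neither a potency, as the read-out comes from one concentration, nor whether the step would hold on a core with clearly measurable inhibition.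

Still open, on these data alone, is whether a methoxy group in place of the hydroxyl, or an amine or a carboxylic acid on the phenyl ring, would move the read-out beyond the scatter of these numbers. Also open, as far as these compounds go, is whether the same change behaves alike at sites other than the one opposite the ring nitrogen.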